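A few compounds are considered here, and "the series" means these few. Any claim that something is new, unique, unknown or untested is made for them only; others in the source may bear on it.

The series shares one core; compound 1 `Nc1cc(N)c2nc(-c3ccccc3)c(Sc3ccc(F)cc3)nc2c1` carries a (4-fluorophenyl)sulfanyl group on it. In a functional assay on MOLT-4 cells (Homo sapiens) for inhibition, read by sulforhodamine B assay, with a stated time of 48 h (on this read-out higher numbers stand for weaker inhibition of growth and lower numbers for stronger inhibition of growth), compound 1 gives only a limit, < 100000 nM, so no number stands for it. Compound 2 `COc1cc(CNc2nc3cc(N)cc(N)c3nc2-c2ccccc2)cc(OC)c1OC` is the other measured member; in this assay compound 2 gives 12300 nM. Among the measured compounds shown here, with a limit for compound 1 and no single-point step between measured compounds, the place of compound 1 among the numbers cannot be fixed beyond that limit, and this is the one piece of evidence at hand: the limit of < 100000 nM in this assay, at which 1 of the 2 values shown sits.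

Compound 3 `Nc1cc(N)c2nc(-c3ccccc3)c(NCc3ccc(F)cc3)nc2c1` is the next member, not yet measured. It differs from compound 1 in one place: (4-fluorobenzyl)amino in place of (4-fluorophenyl)sulfanyl on an aromatic carbon. For the measured compounds named here, no measured step of this kind exists, so its size is not known from the data. Going by the values given here, the expectation is that compound 3 reaches a number inside the range of this assay, in the direction of stronger growth inhibition, resting on compound 2, whose value of 12300 nM is the only number in the set. The step from compound 1 to compound 3 is expected as a step that the limit leaves unreadable from compound 1 to compound 3. Compound 3 is expected to give 15000 nM, between 4000 nM and 60000 nM.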

Compound 3, concentration for 50% growth inhibition: < 100000 nM
Compound 3 was reported as a limit; the forecaster's own chance of this, stated with the estimate: 15%; the middle value lies beyond the limit too.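

No step from compound 1 to compound 3 can be read in this assay, since each of the two compounds is reported only as a limit: the limit of < 100000 nM in this assay, at which 2 of the 3 values shown sit.

The compounds shown leave open whether (4-fluorobenzyl)amino in place of (4-fluorophenyl)sulfanyl on an aromatic carbon changes growth inhibition at all, and by how much.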